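The compounds below may be only part of what the source reports. "The series", "measured", "known", "first", "only" and "open" are said of these compounds alone.

Compound 1 `COC1(c2cc(F)cc(OCc3ccc(-n4ccnc4C)cc3)c2)CCOCC1` carries a methoxy on a saturated ring carbon and gives 60 nM in an assay on blood for inhibition of Polyunsaturated fatty acid 5-lipoxygenase (Homo sapiens); a higher number here means a weaker inhibitor, a lower number a stronger inhibitor. Going by the values given here, compound 2 `Cc1nccn1-c1ccc(COc2cc(F)cc(C3(C(=O)N(C)C)CCOCC3)c2)cc1` gives 810 nM in this assay and stands highest of the two numbers measured so far; the single known step, a 14-fold higher number from compound 1 to compound 2 (1.13 log units; beyond the scatter), is large. Compound 3 `CSC1(c2cc(F)cc(OCc3ccc(-n4ccnc4C)cc3)c2)CCOCC1` differs from compound 2 by methylsulfanyl in place of dimethylcarbamoyl on a saturated ring carbon. The measured step of a 14-fold higher number from compound 1 to compound 2 (1.13 log units; beyond the scatter) bears on this directly, and as methylsulfanyl resembles methoxy more than dimethylcarbamoyl, the change is expected to run back the other way, giving an 8.1-fold lower number from compound 2 to compound 3 (0.91 log units; beyond the scatter) in this assay. For compound 3 the estimate is 100 nM, ranging from 30 nM to 350 nM.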

Compound 3, half-maximal inhibitory concentration: 72 nM
Compound 3: the middle estimate sits 1.4-fold (0.14 log units) above what was measured, and the stated range covers the measured number.
By their numbers in this assay, from the lowest: compounds 1 and 3 (each within the scatter of the next); then compound 2.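

In this assay, the large step of an 11-fold lower number from compound 2 to compound 3 (1.05 log units; beyond the scatter) shows that the loss seen with dimethylcarbamoyl on this saturated ring carbon is not a fixed feature of the series: methylsulfanyl recovers it. Methylsulfanyl and methoxy cannot be told apart at this position, as the step of a 1.2-fold higher number from compound 1 to compound 3 (0.08 log units; within the scatter) shows. Nothing given here explains why dimethylcarbamoyl differs from these two groups.

Going by these compounds, it remains open whether an amine, a hydroxyl or a longer chain such as ethoxy on this ring carbon would match methoxy and methylsulfanyl or fall toward dimethylcarbamoyl.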